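From 1-methoxyethyl to 1-ethoxyethyl: compound 4 awaits measurement

The compounds below may be only part of what the source reports. "The series", "measured", "known", "first", "only" and "open" are said of these compounds alone.

Within the data shown here, in a functional assay on OCI-Ly3 cells (Homo sapiens) for antiproliferative activity (on this read-out lower numbers stand for an effect already at smaller amounts and higher numbers for an effect only at larger amounts of compound), compound 3 (`COC(C)c1c(NC(=O)Nc2cnc(-n3nccn3)c(Cl)c2)cnc2ccc(F)cc12`) gives 270 nM as the lowest of three numbers so far. Compound 1 (`O=C(Nc1cnc(-n2nccn2)c(Cl)c1)Nc1cnc2ccc(F)cc2c1C1CC1`) gives 720 nM and compound 2 (`CCOC(C)c1c(NC(=O)Nc2cnc(-n3nccn3)c(Cl)c2)cnc2ccccc12`) gives 1530 nM on the same read-out. Among the measured compounds shown here, compound 4 (`CCOC(C)c1c(NC(=O)Nc2cnc(-n3nccn3)c(Cl)c2)cnc2ccc(F)cc12`) has 1-ethoxyethyl in place of the 1-methoxyethyl of compound 3 (methyl in place of hydrogen on a saturated chain carbon bound to an oxygen on a saturated carbon) as its only change. For the measured compounds named here, the one measured step at this group is a 2.7-fold lower number from compound 1 to compound 3 (0.43 log units; beyond the scatter) and is modest, but it replaces cyclopropyl and says little about methoxy to ethoxy. Compound 2 carries 1-ethoxyethyl on a different core and shows a higher number than compound 3, so a small rise is expected. The estimated step in this assay is a 1.5-fold higher number from compound 3 to compound 4 (0.17 log units; within the scatter) and stays within the scatter. Compound 4 is estimated at 400 nM within an expected range of 150 nM to 1100 nM on this measure.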

Compound 4, half-maximal effective concentration: 590 nM
Compound 4: middle estimate off by 1.5-fold (0.17 log units), on the low side; the range from low to high includes it.
By their numbers in this assay, from the lowest: compound 3; then compounds 4 and 1 (each within the scatter of the next); then compound 2.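

In this assay the single added methyl at this position already counts (a 2.2-fold higher number from compound 3 to compound 4 (0.34 log units; beyond the scatter)), so methoxy to ethoxy is not a silent change here. With 1-ethoxyethyl held constant, fluoro in place of hydrogen on an aromatic carbon also counts (a 2.6-fold lower number from compound 2 to compound 4 (0.41 log units; beyond the scatter)). Unlike the step from cyclopropyl to 1-methoxyethyl (a 2.7-fold lower number from compound 1 to compound 3 (0.43 log units; beyond the scatter)), the step to 1-ethoxyethyl stays within the scatter (a 1.2-fold lower number from compound 1 to compound 4 (0.09 log units; within the scatter)). Nothing available gives a reason for these steps. Going by these compounds, whether a longer chain such as 1-propoxyethyl would follow ethoxy, or a hydroxyl or an amine would replace the ether, remains open.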